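Thiophene exchange on the carbonyl of compound 1

The source may hold more compounds than are shown below. What is called first, only, known or untested is meant among the compounds shown, and "the series" means these compounds.

In a functional assay on HUVEC cells (Homo sapiens), read by BrdU incorporation, with a stated time of 72 h (a lower number here means a stronger inhibitor, a higher number a weaker inhibitor), compound 1 (`Cc1ccc2nc(Cl)c(/C=C/C(=O)c3ccc(Cl)s3)cc2c1`) gives 59.4 nM, the lower of the two numbers available. Compound 2 (`Cc1cccc2cc(/C=C/C(=O)c3ccc(Br)s3)c(Cl)nc12`) gives 243 nM, a gap beyond the usual scatter, but the two compounds differ in more than one place, so no single change can be read from them. Compound 3 (`Cc1ccc2nc(Cl)c(/C=C/C(=O)c3cc(C)sc3C)cc2c1`) keeps the core of compound 1 and carries 2,5-dimethylthiophen-3-yl in place of 5-chlorothiophen-2-yl on a carbonyl carbon. Neither measured compound carries the entering group, so the expectation is loose. With compound 1 at 59.4 nM as the low end of the measured numbers, a shift towards weaker inhibition in this assay is expected, and the estimated step of a 3.4-fold higher number from compound 1 to compound 3 (0.53 log units; beyond the scatter) lies beyond the scatter. For compound 3 the estimate is 200 nM, with an expected range of 60 nM to 700 nM.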

Compound 3, half-maximal inhibitory concentration: 229 nM
Estimate against measurement, compound 3: 1.1-fold (0.06 log units) below; the measured number falls inside the stated range.
By their numbers in this assay, from the lowest: compound 1; then compounds 3 and 2 (each within the scatter of the next).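

Among the compounds shown here, the exchange on the carbonyl carbon gives the first single-change reading: in this assay, 2,5-dimethylthiophen-3-yl in place of 5-chlorothiophen-2-yl gives a 3.9-fold higher number from compound 1 to compound 3 (0.59 log units; beyond the scatter). This position therefore responds to the choice of thiophene, and on the core of compound 1 the 5-chlorothiophen-2-yl group gives the stronger inhibition of the two. No measurement at hand accounts for the step.

On these data alone, the exchange alters the ring substituents and the ring attachment together, so the share of each in the step remains open. Also open, as far as these compounds go, is whether this position tolerates a ring other than thiophene, such as a phenyl ring or a pyridine, or a thiophene bearing an amine.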